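Methyl on the chain carbon bearing the azole nitrogen

A few compounds are considered here, and "the series" means these few. Any claim that something is new, unique, unknown or untested is made for them only; others in the source may bear on it.

For the measured compounds named here, compound 1 `Sc1nccn1CCCc1ccccc1` is measured in an assay on isolated protein for inhibition of Dopamine beta-hydroxylase (Bos taurus) (a lower number here means a stronger inhibitor, a higher number a weaker inhibitor), at 16000 nM, the second highest of the three numbers so far. Compound 2 `CC(CCn1ccnc1S)c1ccccc1` gives 18000 nM in this assay, and compound 3 `Oc1ccc(CCCn2ccnc2S)cc1` gives 2200 nM. The step from compound 1 to compound 4 `CC(CCc1ccccc1)n1ccnc1S` is methyl in place of hydrogen on a saturated chain carbon bound to an aromatic nitrogen and a saturated chain carbon. The step most like it is a methyl on another chain carbon, a 1.1-fold higher number from compound 1 to compound 2 (0.05 log units; within the scatter), which stayed within the scatter; the hydroxy step, a 7.3-fold lower number from compound 1 to compound 3 (0.86 log units; beyond the scatter), touches an aromatic carbon and does not bear on a chain methyl. With one chain methyl having left the number unchanged, no step beyond the scatter is expected, so no change at the digits printed from compound 1 to compound 4 (within the scatter) is the estimate. Compound 4 is expected near 16000 nM, between 6000 nM and 42000 nM.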

Compound 4, half-maximal inhibitory concentration: 325000 nM
For compound 4 the middle estimate is 20-fold (1.31 log units) below the measured one; measured number above the stated range.
By their numbers in this assay, from the lowest: compound 3; then compounds 1 and 2 (each within the scatter of the next); then compound 4.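

In this assay, a chain methyl is not neutral at every carbon: on a saturated chain carbon bound to an aromatic nitrogen and a saturated chain carbon, the change gives a 20-fold higher number from compound 1 to compound 4 (1.31 log units; beyond the scatter), whereas the methyl on the chain carbon bound to an aromatic carbon gives a 1.1-fold higher number from compound 1 to compound 2 (0.05 log units; within the scatter). Across these two steps, the outcome depends on which chain carbon carries the methyl. No available evidence accounts for this difference. Still open, on these data alone, is how an ethyl group would behave at this place, and whether hydroxy on the aromatic carbon, as in compound 3, would retain its step with this methyl present.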